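Swapping the amide aryl group for a chloropyridine

The source may report more compounds than this note shows. Statements on the series, on what has been measured and on what is new or still open speak of the compounds shown alone.

Three compounds built on one shared core differ only in the aromatic group attached to the amide carbonyl. In a functional assay on HeLa cells (Homo sapiens) for antiproliferative activity, read by CCK-8 assay, with a stated time of 72 h (on this read-out higher numbers stand for weaker inhibition and lower numbers for stronger inhibition), compound 1 `O=C(Nc1cccc(-c2oc3cc(-c4ccc(F)cc4)ccc3c(=O)c2O)c1)c1ccccc1F` gives 5630 nM, compound 2 `Cc1ccc(C(=O)Nc2cccc(-c3oc4cc(-c5ccc(F)cc5)ccc4c(=O)c3O)c2)cc1` gives 6190 nM, and compound 3 `Cc1cc(C(=O)Nc2cccc(-c3oc4cc(-c5ccc(F)cc5)ccc4c(=O)c3O)c2)ccc1F` gives 18900 nM. Compound 3 thus stands highest of the three, meaning it is the weakest inhibitor here: the step of a 3.4-fold higher number from compound 1 to compound 3 (0.53 log units; beyond the scatter) and the step of a 3.1-fold higher number from compound 2 to compound 3 (0.48 log units; beyond the scatter) both lie beyond the scatter, whereas the step of a 1.1-fold higher number from compound 1 to compound 2 (0.04 log units; within the scatter) does not.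

Compound 4 `O=C(Nc1cccc(-c2oc3cc(-c4ccc(F)cc4)ccc3c(=O)c2O)c1)c1ccc(Cl)nc1` changes the same position once more: 6-chloropyridin-3-yl in place of 4-fluoro-3-methylphenyl on a carbonyl carbon. For the measured compounds named here, no measured pair carries this particular exchange, so the only guide is how much the earlier aryl swaps moved the read-out. Those steps were modest in size and went in both directions, which suggests that another aryl swap should shift the number by a comparable, limited amount rather than dramatically. The expected step for compound 4 is a 2.1-fold lower number from compound 3 to compound 4 (0.32 log units; beyond the scatter), a mild move back toward the stronger end seen in this small set, with a range wide enough to include no change at all. Compound 4 is therefore estimated at 9000 nM, with a range from 3500 nM to 25000 nM.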

Compound 4, half-maximal inhibitory concentration: 4080 nM
Compound 4: middle estimate off by 2.2-fold (0.34 log units), on the high side; low and high end bracket the measured number.
By their numbers in this assay, from the lowest: compounds 4, 1 and 2 (each within the scatter of the next); then compound 3.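

In this assay, the 6-chloropyridin-3-yl group puts a ring nitrogen and a chlorine at this position, on a carbonyl carbon bound to the amide-type nitrogen, and a 4.6-fold lower number from compound 3 to compound 4 (0.67 log units; beyond the scatter) is the largest step seen here so far. Compared with the other two groups, the new ring sits level: a 1.5-fold lower number from compound 2 to compound 4 (0.18 log units; within the scatter) and a 1.4-fold lower number from compound 1 to compound 4 (0.14 log units; within the scatter) both stay within the scatter, so a ring with a hetero atom serves as well here as 2-fluorophenyl or 4-methylphenyl, and compound 3 now stands alone as the weakest of the four. No supporting measurement is available to say what lies behind these differences.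

Compound 4 brings in the ring nitrogen and the chlorine together, so the compounds shown leave open what each contributes on its own. Also open, on these data alone, is how this position responds to a group that is not an aromatic ring at all, such as a morpholine, a plain alkyl chain or a chain ending in a carboxylic acid.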